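Isopropyl for methyl on a hormone-sensitive lipase isoxazolone carbamate

This account rests on a few compounds, and the source may have more. Where it says the series, first, only, none or still open, it means among the compounds named here.

Measured compounds:
compound 1 `Cc1c(Sc2ccc(Cl)cc2)c(=O)on1C(=O)N1CCCCC1` — 6 nM
compound 2 `Cc1c(C)n(C(=O)N2CCCCC2)oc1=O` — 13 nM

In an assay (strain Wistar) for inhibition of Hormone-sensitive lipase (Rattus norvegicus), read by spectrophotometry (on this read-out lower numbers stand for stronger inhibition and higher numbers for weaker inhibition), compound 1 gives 6 nM, and compound 2 gives 13 nM, the highest of the two numbers and beyond the scatter from compound 1. Compound 3 `Cc1c(C(C)C)c(=O)on1C(=O)N1CCCCC1` is not yet measured. It differs from compound 2 by isopropyl in place of methyl on an aromatic carbon. Among the compounds with values here, with only these two compounds there is no measured step to lean on; compound 1 shows that a larger group at this place is compatible with a low number. The expected step from compound 2 to compound 3 is a 1.4-fold lower number from compound 2 to compound 3 (0.16 log units; within the scatter), within the scatter. Compound 3 is estimated at 9 nM, between 3 nM and 30 nM.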

Compound 3, half-maximal inhibitory concentration: 2 nM
Compound 3: middle estimate off by 4.5-fold (0.65 log units), on the high side, and the stated range ends above it.
By their numbers in this assay, from the lowest: compound 3; then compound 1; then compound 2.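

In this assay, isopropyl in place of methyl on this aromatic carbon gives a 6.5-fold lower number from compound 2 to compound 3 (0.81 log units; beyond the scatter), a step beyond the scatter. This position therefore responds to a change between two small alkyl groups alone, with no ring and no hydrogen-bond donor or acceptor entering. No measurement at hand gives a reason for the size of this step. The compounds shown leave open how ethyl, cyclopropyl or tert-butyl would read at this place, and whether an amine or a carboxylic acid there would keep the number low.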